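Aryl piperazine anilides: pyrimidine in place of chloropyridine

The source may report more compounds than this note shows. Statements on the series, on what has been measured and on what is new or still open speak of the compounds shown alone.

The series shares an anilide-piperazine core. Compound 1 `Cc1cccc(NC(=O)CN2CCN(c3ccc(Cl)cn3)CC2)c1` gives 12.5 nM in an assay on HEK293 cells for displacement of a labelled ligand from D(4) dopamine receptor (Homo sapiens), read by scintillation counting, with a stated time of 90 min (a lower number here means a stronger inhibitor, a higher number a weaker inhibitor), the lowest of the two numbers in hand. Compound 2 `Cc1cccc(NC(=O)CCN2CCN(c3ncccn3)CC2)c1` differs from compound 1 in several places. In this assay compound 2 gives 33 nM, and the gap between the two lies beyond the usual scatter. Compound 3 `Cc1cccc(NC(=O)CN2CCN(c3ncccn3)CC2)c1` has not been measured. Relative to compound 1 the change is pyrimidin-2-yl in place of 5-chloropyridin-2-yl on an amine nitrogen in a ring. Going by the values given here, no measured step covers this exact exchange, so the only guide is that compound 2, which also carries the pyrimidin-2-yl group, gives 33 nM. On that basis a small weakening is expected, a 2.0-fold higher number from compound 1 to compound 3 (0.30 log units; within the scatter), close to the edge of the scatter. For compound 3 the expected value in this assay is 25 nM, with a range from 8 nM to 80 nM.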

Compound 3, inhibition constant: 5.66 nM
Estimate against measurement, compound 3: 4.4-fold (0.65 log units) above, and the stated range ends above it.
By their numbers in this assay, from the lowest: compound 3; then compound 1; then compound 2.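

On the amine nitrogen in the ring, 5-chloropyridin-2-yl is not needed for a low number in this assay: pyrimidin-2-yl in its place gives a 2.2-fold lower number from compound 1 to compound 3 (0.34 log units; beyond the scatter) and is the lowest value in the set. The same group also appears in compound 2 at 33 nM and in compound 3 at 5.66 nM, so the higher number of compound 2 cannot be attributed to pyrimidin-2-yl alone. Nothing in hand accounts for the lower number of compound 3.

The exchange removes the chlorine and adds a ring nitrogen at once, so plain pyridin-2-yl and 5-chloropyrimidin-2-yl on the same core would be needed to separate the two changes. Going by these compounds, whether the gain holds with a different group on the anilide ring, such as methoxy in place of methyl, also remains open.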